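This account rests on a few compounds, and the source may have more. Where it says the series, first, only, none or still open, it means among the compounds named here.

In a functional assay on the whole organism with Rattus norvegicus as the target (a lower number here means that less compound is needed, a higher number that more compound is needed for the effect), three compounds have a measured dose so far. Compound 1 `Nc1nc2ccc(OC(F)(F)C(F)(F)F)cc2s1` gives 2.5 mg/kg in this test, compound 2 `Cn1c(=N)sc2cc(OC(F)(F)F)ccc21` gives 5 mg/kg and compound 3 `CCn1c(=N)sc2cc(OC(F)(F)F)ccc21` gives 5 mg/kg as its reading. Compound 3 thus stands level with compound 2, and its gap to compound 1 lies within the scatter. Compound 4 `CCCn1c(=N)sc2cc(OC(F)(F)F)ccc21` differs from compound 3 by one small change methyl in place of hydrogen on a saturated chain carbon, two bonds along the chain from an aromatic nitrogen in the chain, namely methyl in place of hydrogen on a saturated chain carbon, two bonds along the chain from an aromatic nitrogen, which takes ethyl to propyl. Among the compounds with values here, only one measured step bears on this, the placing of methyl on a saturated chain carbon bound to an aromatic nitrogen, and it showed no change at the digits printed from compound 2 to compound 3 (within the scatter) as its result. That is a single example, so it offers limited guidance, but it gives no reason to expect a shift beyond the scatter. The expected outcome in this assay is no change at the digits printed from compound 3 to compound 4 (within the scatter) with no direction favoured. Compound 4 is expected at 5 mg/kg with 2.3 mg/kg to 11 mg/kg as the estimated range.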

Compound 4, dose for half-maximal effect: 4.5 mg/kg
Beside the measured number, compound 4's estimate is 1.1-fold (0.05 log units) above it, within the range that was stated.
By their numbers in this assay, from the lowest: compounds 1, 4, 2 and 3 (each within the scatter of the next).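

In this assay the step from ethyl to propyl on the aromatic nitrogen gives a 1.1-fold lower number from compound 3 to compound 4 (0.05 log units; within the scatter) and the step from methyl to propyl gives a 1.1-fold lower number from compound 2 to compound 4 (0.05 log units; within the scatter) as its result. Within the data shown here, the change now reaches one carbon further out, two bonds along the chain from the aromatic nitrogen, and methyl, ethyl and propyl at this place read alike, where the earlier compounds offered only a single step at the carbon bound to that nitrogen. Nothing in the available data offers a reason for this.

Going by these compounds, whether this flat reading holds for a longer chain such as butyl or a branched one such as isopropyl remains open. So does the effect of a chain ending in an amine or a carboxylic acid, or of a benzyl group at this place.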